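Hydroxamic acid series: acyl variation on the ring nitrogen

The source may report more compounds than this note shows. Statements on the series, on what has been measured and on what is new or still open speak of the compounds shown alone.

Of the compounds shown here, two have been measured in an assay on isolated protein for inhibition of histone deacetylase 8 (Homo sapiens), read by fluorescence, with a stated time of 30 min; on this read-out higher numbers stand for weaker inhibition and lower numbers for stronger inhibition. Compound 1 `O=C(COc1ccc2c(c1)CN(C(=O)CCc1ccccc1)[C@H](C(=O)Nc1ccccc1)C2)NO` gives 759 nM in this assay. Compound 2 `COc1ccc(NC(=O)[C@@H]2Cc3ccc(OCC(=O)NO)cc3CN2C(=O)CNC(=O)OC(C)(C)C)cc1` gives 514 nM in this assay; its number and that of compound 1 lie within the scatter of each other, so the two compounds cannot be told apart on this read-out. For the measured compounds named here, no step between measured compounds that differ in one place is available, so nothing is yet known about how a change of the acyl group on the ring nitrogen moves the number.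

Compound 3 `COc1ccc(NC(=O)[C@@H]2Cc3ccc(OCC(=O)NO)cc3CN2C(=O)[C@@H]2CCCN2C(=O)OC(C)(C)C)cc1` is not yet measured. Compared with compound 2 the change is 1-(tert-butoxycarbonyl)pyrrolidin-2-yl in place of ((tert-butoxycarbonyl)amino)methyl on a carbonyl carbon. Going by the values given here, the five-membered ring of the entering group and the change from one hydrogen-bond donor to none are the counted differences; with no measured step to lean on, the expectation is a step of no more than the scatter in this assay, in either direction. The expected step of a 1.1-fold lower number from compound 2 to compound 3 (0.06 log units; within the scatter) is accordingly small. Compound 3 is estimated at 450 nM, with a range of 150 nM to 1500 nM.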

Compound 3, half-maximal inhibitory concentration: 212 nM
The estimate for compound 3 lay 2.1-fold (0.33 log units) above the measured number; the measured number falls inside the stated range.
By their numbers in this assay, from the lowest: compound 3; then compounds 2 and 1 (each within the scatter of the next).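

In this assay, for the compounds shown here, 1-(tert-butoxycarbonyl)pyrrolidin-2-yl in place of ((tert-butoxycarbonyl)amino)methyl on a carbonyl carbon gives a 2.4-fold lower number from compound 2 to compound 3 (0.38 log units; beyond the scatter), the first measured step and a modest one. It shows that the group on this carbonyl carbon, itself bound to the amide-type nitrogen in a ring, can move the number beyond the scatter, and that here the move is towards stronger inhibition. The entering group differs from the leaving group at once in its five-membered non-aromatic ring, its defined stereocentre, its larger heavy-atom count and its lack of a hydrogen-bond donor, and nothing measured here separates these differences or explains the step.

Still open, going by these compounds, is which of these differences carries the step, a question that the opposite configuration at the stereocentre or a six-membered piperidine ring in place of the pyrrolidine could address. Also open is whether the tert-butoxycarbonyl group matters at all, since the compounds shown include no free pyrrolidine amine or acetyl-capped analogue at this place.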